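A Methyl on the Ring Amide Nitrogen of Compound 2

The compounds below may be only part of what the source reports. "The series", "measured", "known", "first", "only" and "open" are said of these compounds alone.

In a functional assay on MCF7 cells (Homo sapiens) for antiproliferative activity, read by MTT assay (on this read-out higher numbers stand for weaker inhibition and lower numbers for stronger inhibition), compound 1 (`NS(=O)(=O)c1ccc(/N=C2\NC(=O)/C(=C3/C(=O)Nc4ccc(F)cc43)S2)cc1`) gives 20500 nM, while compound 2 (`NS(=O)(=O)c1ccc(/N=C2\NC(=O)/C(=C3/C(=O)Nc4ccc(Cl)cc43)S2)cc1`) gives 3960 nM, the lower of these two numbers. Compound 3 (`Cc1ccc2c(c1)/C(=C1/S/C(=N/c3ccc(S(N)(=O)=O)cc3)NC1=O)C(=O)N2`) gives > 200000 nM, which is a limit of the assay. Compound 4 (`CN1C(=O)/C(=C2\S/C(=N/c3ccc(S(N)(=O)=O)cc3)NC2=O)c2cc(Cl)ccc21`) differs from compound 2 by methyl in place of hydrogen on an amide-type nitrogen in a ring. Within the data shown here, no measured step touches that place. The nearest guides are changes on an aromatic carbon: a 5.2-fold lower number from compound 1 to compound 2 (0.71 log units; beyond the scatter), and the large at least 50-fold higher number from compound 2 to compound 3 (1.70 log units; beyond the scatter), which also brings in a methyl. A modest rise in this assay is therefore expected, with much uncertainty. The expected change is a 2.3-fold higher number from compound 2 to compound 4 (0.36 log units; beyond the scatter). The estimated value for compound 4 is 9000 nM, within an expected range of 2000 nM to 50000 nM.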

Compound 4, half-maximal inhibitory concentration: > 200000 nM
Compound 4: only a limit was reported; the forecaster's own chance of this, stated with the estimate: 10%; middle value at least 22-fold (1.34 log units) away from the limit.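

In this assay, this ring amide nitrogen proves far less forgiving than the aromatic carbon changes alone could show: methyl in place of hydrogen gives an at least 50-fold higher number from compound 2 to compound 4 (1.70 log units; beyond the scatter). Compound 4 gives > 200000 nM, which is a limit of the assay and not a number. The step therefore sets only a minimum size, and the same ceiling appears elsewhere in the series: the limit of > 200000 nM in this assay, at which 2 of the 4 values shown sit.

From the compounds shown here alone, whether the drop comes from losing the amide hydrogen or from adding the methyl stays open. So does the effect of an ethyl, a longer chain or an amine-bearing chain on this nitrogen.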